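The source may report more compounds than this note shows. Statements on the series, on what has been measured and on what is new or still open speak of the compounds shown alone.

Compound 1 `CC(C)C(Nc1nnc[nH]1)c1ccc(-c2ccc3cccc(F)c3c2)[nH]c1=O` is the starting point. In an ADME assay on microsomes from liver (Homo sapiens) for metabolic stability (on this read-out lower numbers stand for a shorter-lived compound and higher numbers for a longer-lived compound), compound 1 gives > 3 h, which is a limit of the assay and not a number (the limit of > 3 h in this assay, at which 1 of the 3 values shown sits). Compound 4 `CC(C)C(c1noc(=O)[nH]1)c1ccc(-c2ccc3cccc(F)c3c2)[nH]c1=O` differs from compound 1 in one place: a group of 6 heavy atoms (2 carbon, 2 nitrogen, 2 oxygen; one five-membered aromatic ring with 3 hetero atoms) in place of a group of 6 heavy atoms (2 carbon, 4 nitrogen; one five-membered aromatic ring with 3 hetero atoms), on a saturated chain carbon bound to an aromatic carbon and a saturated chain carbon. Two measured steps from compound 1 bear on this, each also replacing the (4H-1,2,4-triazol-3-yl)amino on a saturated chain carbon bound to an aromatic carbon and a saturated chain carbon with a five-membered aromatic ring. Compound 2 `CC(C)C(c1nnc[nH]1)c1ccc(-c2ccc3cccc(F)c3c2)[nH]c1=O` gives 0.905 h in this assay, a step of an at least 3.3-fold lower number from compound 1 to compound 2 (0.52 log units; beyond the scatter). Compound 3 `CC(C)C(c1cnc(N)s1)c1ccc(-c2ccc3cccc(F)c3c2)[nH]c1=O` gives 0.178 h in this assay, a step of an at least 16-fold lower number from compound 1 to compound 3 (1.22 log units; beyond the scatter). Compound 4 is therefore expected to show a lowering, an at least 3.0-fold lower number from compound 1 to compound 4 (0.47 log units; beyond the scatter). Compound 4 is estimated at 1 h, within 0.4 h to 2.5 h.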

Compound 4, half-life: > 3 h
Compound 4: no number, only a limit; the forecaster's own chance of this, stated with the estimate: 5%; middle value at least 3.0-fold (0.47 log units) away from the limit.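

A five-membered aromatic ring bound directly to this saturated chain carbon does not always shorten the half-life in this assay, since compound 4 goes against the lowering seen with compound 2 and compound 3. The choice of ring matters here, with an at least 3.3-fold higher number from compound 2 to compound 4 (0.52 log units; beyond the scatter) and an at least 16-fold higher number from compound 3 to compound 4 (1.22 log units; beyond the scatter). Compound 4 gives a limit and not a number, like compound 1, so the step between them cannot be read: the limit of > 3 h in this assay, at which 2 of the 4 values shown sit.

Which of the two compounds lasts longer therefore stays open. Going by these compounds, it also remains unknown whether a carboxylic acid or an amide on this carbon would give a long half-life too.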